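The compounds below may be only part of what the source reports. "The series", "measured", "known", "first", "only" and "open" are said of these compounds alone.

In an assay on membranes from HEK293 cells for displacement of a labelled ligand from Type-2 angiotensin II receptor (Homo sapiens), read by radioligand binding (a higher number here means a weaker inhibitor, a lower number a stronger inhibitor), compound 1 `CCCc1ccc(S(=O)(=O)NC(=O)OCCCC(F)(F)F)c(-c2ccc(Cn3c(C(C)(C)C)nc4ccccc43)cc2)c1` gives 4.5 nM.
In this assay compound 2 `CCCCOC(=O)NS(=O)(=O)c1ccc(CCC)cc1-c1ccc(Cn2c(-c3ccccc3)nc3ccccc32)cc1` gives 590 nM.

Compound 2 has the highest of the two numbers; the nearest, compound 1, differs from it in more than one place, so the gap between them cannot be tied to a single change. Compound 3 `CCCCOC(=O)NS(=O)(=O)c1ccc(CCC)cc1-c1ccc(Cn2c(C3CCC3)nc3ccccc32)cc1` is not yet measured and differs from compound 2 by cyclobutyl in place of phenyl on an aromatic carbon. With no measured step of this kind shown, the direction is uncertain, though a move toward a lower number is expected. Compound 3 is estimated at 60 nM, between 10 nM and 400 nM, an expected step of a 9.8-fold lower number from compound 2 to compound 3 (0.99 log units; beyond the scatter).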

Compound 3, inhibition constant: 12 nM
Compound 3: middle estimate off by 5.0-fold (0.70 log units), on the high side, within the range that was stated.
By their numbers in this assay, from the lowest: compound 1; then compound 3; then compound 2.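

In this assay, going by these compounds alone, the swap of phenyl for cyclobutyl on the carbon between two ring nitrogen atoms gives a 49-fold lower number from compound 2 to compound 3 (1.69 log units; beyond the scatter) and is the first change at this position that can be read alone. An aromatic ring on this carbon is therefore not needed for a low number, and here the non-aromatic ring does better. No measurement shown bears on why the step arises. On these data alone, whether ring size or the loss of the aromatic ring matters more stays open. As far as these compounds go, how a cyclopropyl or cyclohexyl ring would behave on this carbon also remains unknown.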